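The source may hold more compounds than are shown below. What is called first, only, known or untested is meant among the compounds shown, and "the series" means these compounds.

Compound 1 `CSc1nc(NCc2ccc(-c3ccccn3)cc2)c2[nH]nc(C(C)C)c2n1` gives 783 nM in a functional assay on HT cells (Homo sapiens) for antiproliferative activity, read by fluorescence, with a stated time of 72 h; on this read-out higher numbers stand for weaker inhibition of growth and lower numbers for stronger inhibition of growth.
Compound 2 `CC(C)c1n[nH]c2c(NCc3ccc(-c4ccccn4)cc3)nc(SCCN)nc12` gives 22 nM in this assay.

Of the two numbers shown, compound 2 stands lowest; its only neighbour is compound 1, separated by a 36-fold lower number from compound 1 to compound 2 (1.55 log units; beyond the scatter). Compound 3 `CC(C)c1n[nH]c2c(NCc3ccc(-c4ccccn4)cc3)nc(SCC(N)=O)nc12` is not yet measured and differs from compound 2 by carbamoyl in place of aminomethyl on a saturated chain carbon bound to a sulfur. Among the compounds with values here, the only step that bears on this change is the one from compound 1 to compound 2, at the same place on the chain, and it was large. That step gives the scale but not the direction of the present change, so compound 3 is estimated at 150 nM (range 40 nM to 600 nM), an expected step of a 6.8-fold higher number from compound 2 to compound 3 (0.83 log units; beyond the scatter).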

Compound 3, concentration for 50% growth inhibition: 192 nM
For compound 3 the middle estimate is 1.3-fold (0.11 log units) below the measured one; low and high end bracket the measured number.
By their numbers in this assay, from the lowest: compound 2; then compound 3; then compound 1.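

Carbamoyl in place of aminomethyl gives up more than half of the gain seen at this saturated chain carbon bound to a sulfur, with an 8.7-fold higher number from compound 2 to compound 3 (0.94 log units; beyond the scatter) in this assay and compound 2 still lowest of the three. Carbamoyl nonetheless keeps part of that gain over hydrogen, leaving a 4.1-fold lower number from compound 1 to compound 3 (0.61 log units; beyond the scatter) on the same read-out. Nothing measured here accounts for the gap between the two groups.

As far as these compounds go, what sets aminomethyl apart from carbamoyl stays open. The compounds shown do not tell how a carboxylic acid, a dimethylamine or a longer chain ending in an amine would fare at this place.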